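Oxadiazolyl ketone in place of the primary amide

This account rests on a few compounds, and the source may have more. Where it says the series, first, only, none or still open, it means among the compounds named here.

For the measured compounds named here, compound 1 `CCN1CCc2c(sc(NC(=O)Nc3ccc(Cl)cc3)c2C(N)=O)C1` in a functional assay (strain AB) with Danio rerio as the target, read by microscopy, with a stated time of 1 h (a higher number here means that more compound is needed for the effect, a lower number that less compound is needed), gives 3120 nM, the highest of the two numbers known so far. Compound 2 `NC(=O)c1c(NC(=O)Nc2ccc(Cl)cc2)sc2c1CCN(CCCNC(=O)CCc1cccnc1)C2` gives 470 nM, reached through a 6.6-fold lower number from compound 1 to compound 2 (0.82 log units; beyond the scatter). Compound 3 `CCN1CCc2c(sc(NC(=O)Nc3ccc(Cl)cc3)c2C(=O)c2nnco2)C1` differs from compound 1 by 1,3,4-oxadiazol-2-yl in place of amino on a carbonyl carbon. Going by the values given here, the only measured step alters a saturated chain carbon near the ring amine nitrogen and leaves the carbonyl carbon untouched, so no measured step bears on this change; no step beyond the scatter is expected in either direction, with wide uncertainty. For compound 3 the estimate is 4000 nM (range 1000 nM to 20000 nM), which is expected to mean a 1.3-fold higher number from compound 1 to compound 3 (0.11 log units; within the scatter).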

Compound 3, half-maximal effective concentration: > 25000 nM
Compound 3: only a limit was reported (the forecaster's own chance of this, stated with the estimate: 15%); middle value at least 6.2-fold (0.79 log units) away from the limit.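

In this assay, for the compounds shown here, the carbonyl carbon proves sensitive to substitution, which the earlier compounds could not show: 1,3,4-oxadiazol-2-yl in place of amino gives an at least 8.0-fold higher number from compound 1 to compound 3 (0.90 log units; beyond the scatter), so this replacement is not tolerated on the core of compound 1. On these data alone, the reading for compound 3 is a limit and not a number, so the true size of the step stays unknown: the limit of > 25000 nM in this assay, at which 1 of the 3 values shown sits.

As far as these compounds go, whether the loss follows from removing amino or from introducing the ring stays open. A methylamino group or a simple methyl on the same carbonyl carbon would separate the two.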